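A few compounds are considered here, and "the series" means these few. Any claim that something is new, unique, unknown or untested is made for them only; others in the source may bear on it.

Working notes on the series. Going by the values given here, compound 3 `Cc1ccccc1N1CCN(C(=S)SCc2ccc3nc(N)nc(N)c3c2)CC1` gives no starting number: in a functional assay on HeLa cells (Homo sapiens) for antiproliferative activity, read by MTT assay, with a stated time of 72 h (on this read-out higher numbers stand for weaker inhibition and lower numbers for stronger inhibition), compound 3 stands as "not determined" (no result reported) and so has no single value to step from. Among the compounds with values here, compound 4 `Cc1ccc(N2CCN(C(=S)SCc3ccc4nc(N)nc(N)c4c3)CC2)c(C)c1` differs from compound 3 by methyl in place of hydrogen on an aromatic carbon as its only change. That change is methyl in place of hydrogen on an aromatic carbon, meta to a methyl group and para to a large group, which turns 2-methylphenyl into 2,4-dimethylphenyl.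

Within the data shown here, only one measured step bears on this change. Compound 1 `Nc1nc(N)c2cc(CSC(=S)N3CCN(c4ccccc4)CC3)ccc2n1` gives 2840 nM in this series and compound 2 `Cc1ccc(N2CCN(C(=S)SCc3ccc4nc(N)nc(N)c4c3)CC2)cc1` gives 2130 nM on the same read-out. The same kind of replacement, methyl in place of hydrogen on an aromatic carbon, shows a 1.3-fold lower number from compound 1 to compound 2 (0.12 log units; within the scatter) as its whole effect on the numbers. This is a single pair, so it supports only a weak expectation. On that basis, no step beyond the scatter is expected in this assay for the added methyl, and no direction can be assigned. With no number for compound 3, the expectation is anchored on the two measured values, with a range widened for that missing reference. For compound 4 the estimated value is 2200 nM with an expected range from 1000 nM to 4800 nM in this assay.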

Compound 4, half-maximal inhibitory concentration: 3190 nM
Compound 4: middle estimate off by 1.5-fold (0.16 log units), on the low side, within the range that was stated.
By their numbers in this assay, from the lowest: compounds 2, 1 and 4 (each within the scatter of the next).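

The step from compound 3 to compound 4 cannot be read, since compound 3 has no value, so this exact change stays unmeasured against its own parent; in this assay the position is seen only through neighbouring pairs, and a second methyl on the aromatic ring of compound 2 gives a 1.5-fold higher number from compound 2 to compound 4 (0.18 log units; within the scatter). The earlier pair showed one methyl on the phenyl ring, whereas the new comparison covers the full replacement, 2,4-dimethylphenyl in place of phenyl, and gives a 1.1-fold higher number from compound 1 to compound 4 (0.05 log units; within the scatter), so even with both methyl groups present the number stays within the scatter of the unsubstituted compound. Nothing on hand gives a reason for these numbers, or for their lying so close together.

All of the compounds shown carry only hydrogen or methyl on this ring, so the reach of the position is still unknown for a chlorine, a methoxy group, an amine or a carboxylic acid placed para to the large group. On these data alone, whether any replacement here moves the number beyond the scatter in this assay stays open, and so does the effect of the 2-methyl group on its own.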